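This account rests on a few compounds, and the source may have more. Where it says the series, first, only, none or still open, it means among the compounds named here.

Going by the values given here, in a functional assay on MCF7 cells (Homo sapiens) for cytotoxicity, read by MTT assay, with a stated time of 72 h (on this read-out higher numbers stand for lower toxicity in this test and lower numbers for higher toxicity in this test), compound 1 `CSc1ccc(CNc2nc(SC)nc3ncccc23)cc1` gives 9130 nM, and this is the only actual number among the three values shown. Compound 2 `COc1ccc(CNc2nc([SeH])nc3ccccc23)cc1` gives > 100000 nM in this assay, which is a limit of the assay rather than a number. Compound 3 `CCCCC[Se]c1nc([Se]CCCCC)c2ccccc2n1` likewise gives > 100000 nM in this assay, again a limit. Among the compounds with values here, two of the three values thus sit at the limit of > 100000 nM in this assay, at which 2 of the 3 values shown sit, so compound 1 is the one compound here that has a measured concentration to build on.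

Compound 4 `CSc1nc(NCc2ccccc2)c2cccnc2n1` has not yet been measured in this assay. It differs from compound 1 in one place: hydrogen in place of methylsulfanyl on an aromatic carbon. The group that leaves sits on an aromatic carbon of a six-membered aromatic ring of carbon only, para to a large group, and only a hydrogen stands there afterwards. No pair of measured compounds that differ in a single place is available, so the size of such a step cannot be read from the data shown. The step is expected to be a 1.6-fold higher number from compound 1 to compound 4 (0.22 log units; within the scatter), a small shift towards a higher concentration, that is, slightly lower toxicity, close to the usual scatter. Compound 4 is therefore estimated to give about 15000 nM in this assay, with a range from 5000 nM to 50000 nM.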

Compound 4, concentration lethal to 50% of the cells: > 100000 nM
Compound 4 ended at the assay's limit; the forecaster's own chance of this, stated with the estimate: 15%; middle value at least 6.6-fold (0.82 log units) from the limit.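

Replacing the methylsulfanyl group with hydrogen on this aromatic carbon gives an at least 10-fold higher number from compound 1 to compound 4 (1.03 log units; beyond the scatter) in this assay, so this single place makes a difference well beyond the scatter. Going by these compounds alone, this is the first pair that differs in only one place, and it shows that the measurable toxicity of compound 1 does not survive the loss of this group. The value of compound 4 is a limit and not a number, so the step has a known minimum but no known full size, and this limit is shared by most of the compounds shown: the limit of > 100000 nM in this assay, at which 3 of the 4 values shown sit.

With hydrogen as the only replacement shown, this pair cannot tell whether the sulfur atom itself is needed or whether another group at the same place, such as a chlorine atom, an amine or the longer ethylsulfanyl chain, would serve equally well. As far as these compounds go, compounds 2 and 3 differ from compound 1 in more than one place, so they cannot be compared with it, and whether this change would have the same effect on a different core also stays open.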